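This account rests on a few compounds, and the source may have more. Where it says the series, first, only, none or still open, it means among the compounds named here.

In a functional assay on HEp-2 cells (Homo sapiens) for cytotoxicity, read by sulforhodamine B assay, with a stated time of 48 h (on this read-out lower numbers stand for stronger inhibition and higher numbers for weaker inhibition), the three measured compounds stand as follows.

Compound 1 `COc1ccc(C2CC(c3cccc4ccccc34)=NN2C(C)=O)cc1`: 3730 nM
Compound 2 `CC(=O)N1N=C(c2cccc3ccccc23)CC1/C=C/c1ccccc1`: 21100 nM
Compound 3 `COc1ccc(C2CC(c3ccc4ccccc4c3)=NN2CC=O)cc1`: 3230 nM

Compound 1 and compound 3 are built from the same atoms joined differently; how their two cores differ is not broken down here. Between compound 1 and compound 2 the change is 2-phenylethenyl in place of 4-methoxyphenyl on a saturated ring carbon, and it gave a 5.7-fold higher number from compound 1 to compound 2 (0.75 log units; beyond the scatter). Compound 4 `O=CCN1N=C(c2ccc3ccccc3c2)CC1/C=C/c1ccccc1` is not yet measured; it differs from compound 3 by 2-phenylethenyl in place of 4-methoxyphenyl on a saturated ring carbon. This is the same kind of change, though around the place the ring atom bears a formylmethyl group in compound 4 where in compound 2 it bears an acetyl group. The expectation rests on carrying over the earlier step, a 5.7-fold higher number from compound 1 to compound 2 (0.75 log units; beyond the scatter), onto compound 3. Compound 4 is therefore expected to give 18000 nM in this assay, between 8000 nM and 40000 nM, an expected step of a 5.6-fold higher number from compound 3 to compound 4 (0.75 log units; beyond the scatter), because compound 3 gives 3230 nM.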

Compound 4, half-maximal inhibitory concentration: 20100 nM
Beside the measured number, compound 4's estimate is 1.1-fold (0.05 log units) below it, and the stated range covers the measured number.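

In this assay, 2-phenylethenyl in place of 4-methoxyphenyl gave a 6.2-fold higher number from compound 3 to compound 4 (0.79 log units; beyond the scatter), and this step agrees with the earlier one: the same change on two cores in this assay, a 5.7-fold higher number (0.75 log units; beyond the scatter) from compound 1 to compound 2 and a 6.2-fold higher number (0.79 log units; beyond the scatter) from compound 3 to compound 4, 1.1-fold (0.04 log units) apart, within the scatter of two such steps The change therefore carried over at much the same size from the core of compound 1, which bears an acetyl group, to the core of compound 3, which bears a formylmethyl group. These two pairs do not show why the number rises, nor whether the step would hold on any further core.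

Both groups compared on this saturated ring carbon contain an aromatic ring of carbon only. Going by these compounds, how an amine, a carboxylic acid or a longer chain at that place would compare remains open.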